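The source may hold more compounds than are shown below. What is called first, only, known or untested is meant among the compounds shown, and "the series" means these compounds.

Compound 3 `COc1cc(-c2nn(-c3cccc(NC(=O)c4ccccc4)c3)cc2-c2ccncc2)ccc1Cl` gives the lowest number of the three measured compounds in a functional assay on MDA-MB-435 cells (Homo sapiens) for inhibition, read by sulforhodamine B assay, with a stated time of 48 h (on this read-out lower numbers stand for stronger inhibition of growth and higher numbers for weaker inhibition of growth), at 189 nM. Compound 1 `COc1cc(-c2nn(-c3cccc(NC(=O)c4cccc(C(F)(F)F)c4)c3)cc2-c2ccncc2)ccc1Cl` gives 705 nM in this assay, and compound 2 `COc1cc(-c2nn(-c3cccc(NC(=O)Nc4ccc(Cl)c(C(F)(F)F)c4)c3)cc2-c2ccncc2)ccc1Cl` gives 683 nM. The step of a 3.7-fold lower number from compound 1 to compound 3 (0.57 log units; beyond the scatter) and the step of a 3.6-fold lower number from compound 2 to compound 3 (0.56 log units; beyond the scatter) both set compound 3 apart from its neighbours, while the step of a 1.0-fold lower number from compound 1 to compound 2 (0.01 log units; within the scatter) shows no change beyond the scatter. Compound 4 `COc1cc(-c2nn(-c3cccc(NC(=O)Nc4ccc(Cl)c(Cl)c4)c3)cc2-c2ccncc2)ccc1Cl` is not yet measured; it differs from compound 3 by (3,4-dichlorophenyl)amino in place of phenyl on a carbonyl carbon. The step from compound 2 to compound 3 bears directly on this change, since it removed a substituted phenylamino group from the carbonyl carbon and lowered the number; compound 4 restores such a group, carrying two chlorines in place of chlorine and trifluoromethyl. Compound 2 carries a closely related group and gives 683 nM, so compound 4 is expected to move back toward that region, an estimated step of a 3.0-fold higher number from compound 3 to compound 4 (0.47 log units; beyond the scatter). Compound 4 is therefore estimated at 560 nM in this assay, with a range from 250 nM to 1300 nM.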

Compound 4, concentration for 50% growth inhibition: 938 nM
Estimate against measurement, compound 4: 1.7-fold (0.22 log units) below; the measured number falls inside the stated range.
By their numbers in this assay, from the lowest: compound 3; then compounds 2, 1 and 4 (each within the scatter of the next).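

The (3,4-dichlorophenyl)amino group on this carbonyl carbon gives a 5.0-fold higher number from compound 3 to compound 4 (0.70 log units; beyond the scatter), so a second substituted phenylamino group also stands apart from the plain phenyl of compound 3 in this assay. Chloro in place of trifluoromethyl on the aromatic carbon changes little, with a 1.4-fold higher number from compound 2 to compound 4 (0.14 log units; within the scatter), and a 1.3-fold higher number from compound 1 to compound 4 (0.12 log units; within the scatter) also stays within the scatter, so compound 1, compound 2 and compound 4 cannot be told apart here, whether the group on the carbonyl carbon is a substituted phenyl or a substituted phenylamino. No measurement shown gives a reason for these steps.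

The compounds leave open whether an unsubstituted phenylamino group on this carbonyl carbon would stay with compound 3 or join the other three, which would separate the added nitrogen from the halogen-bearing substituents. On these data alone, a methoxy group or a carboxylic acid on the phenyl of compound 3 also remains open.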